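The source may report more compounds than this note shows. Statements on the series, on what has been measured and on what is new or still open speak of the compounds shown alone.

Compound 1 `CNC(=O)c1cc(C(=O)N[C@H]2[C@@H]3COC[C@@H]32)cc2c1OC[C@H]2c1cccc(OC)c1`: >= 186 ug/mL (a limit)
Compound 2 `CNC(=O)c1cc(C(=O)NC2CC2)cc2c1OC[C@H]2c1cccc(OC)c1`: >= 161 ug/mL (a limit)

In a physicochemical assay for solubility (on this read-out lower numbers stand for lower solubility and higher numbers for higher solubility), compound 2 has only a limit, >= 161 ug/mL, and no exact number. Compound 1 also has only a limit, >= 186 ug/mL. Among the measured compounds shown here, the one measured step, a step that the two limits leave unreadable from compound 1 to compound 2, sits on an amide-type nitrogen. Compound 3 `CNC(=O)c1cc(C(=O)NC2CC2)cc2c1OC[C@H]2c1ccc(F)cc1` changes elsewhere: 4-fluorophenyl in place of 3-methoxyphenyl on a saturated ring carbon. In words, 4-fluorophenyl replaces 3-methoxyphenyl on a saturated ring carbon. For the measured compounds named here, no measured step bears on this swap, so in this assay no step beyond the scatter is expected, in either direction. The expected change is an at least 1.0-fold lower number from compound 2 to compound 3 (0.03 log units; that floor lies within the scatter). For compound 3 the estimate is 150 ug/mL, with an expected range of 70 ug/mL to 170 ug/mL.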

Compound 3, solubility: 40 ug/mL
The estimate for compound 3 lay 3.8-fold (0.57 log units) above the measured number; the whole stated range lies above it.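

In this assay, putting 4-fluorophenyl in place of 3-methoxyphenyl on a saturated ring carbon gives an at least 4.0-fold lower number from compound 2 to compound 3 (0.60 log units; beyond the scatter). Among the compounds shown here, this is the first step here that can be read, since the earlier step on the amide-type nitrogen lies between two limits and cannot be read. Its size is only a floor because the number for compound 2 is a limit: the limit of >= 161 ug/mL in this assay, at which 1 of the 3 values shown sits.

This one swap changes both the substituent and its place on the phenyl ring, so the compounds shown cannot separate the two. Plain phenyl or 4-methoxyphenyl at this carbon would help to tell them apart.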